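Swapping Chloro for Benzylamino: Expected Effect on Cytotoxicity

The source may report more compounds than this note shows. Statements on the series, on what has been measured and on what is new or still open speak of the compounds shown alone.

Measured compounds:
- compound 1 `N#Cc1c(-c2c[nH]c3ccccc23)cc(-c2ccc3c(c2)CCCC3)[nH]c1=O`: > 100000 nM
- compound 2 `CC(C)c1ccc(-c2cc(-c3ccc4c(c3)CCCC4)[nH]c(=S)c2C#N)cc1`: > 100000 nM
- compound 3 `CC(C)c1ccc(-c2cc(-c3ccc4c(c3)CCCC4)nc(Cl)c2C#N)cc1`: 8400 nM

The three measured compounds were tested in an ADME assay on RAW264.7 cells (Mus musculus) for cytotoxicity, with a stated time of 24 h; a higher number here means a weaker inhibitor, a lower number a stronger inhibitor. Compound 1 reaches only a limit of the assay, > 100000 nM, with no number behind it. Compound 2 likewise sits at a limit of the assay, > 100000 nM. Among the compounds with values here, compound 3 is the one compound that gives a number, 8400 nM, so it is the only point on the scale from which any step can be judged; the other two values tell nothing beyond (the limit of > 100000 nM in this assay, at which 2 of the 3 values shown sit).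

Compound 4 `CC(C)c1ccc(-c2cc(-c3ccc4c(c3)CCCC4)nc(NCc3ccccc3)c2C#N)cc1` has not yet been measured. It differs from compound 3 in one place: benzylamino in place of chloro on an aromatic carbon. Within the data shown here, no step between two measured compounds shows what such a swap does in this assay, so there is no measured precedent to lean on. With nothing to point to, the expectation is a modest step at most, in either direction, and quite possibly none beyond the scatter; a step of a 1.2-fold higher number from compound 3 to compound 4 (0.08 log units; within the scatter) is estimated. On that basis compound 4 is expected to give about 10000 nM in this assay, within a range from 3000 nM to 40000 nM.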

Compound 4, half-maximal inhibitory concentration: > 50000 nM
Compound 4: only a limit was reported; the forecaster's own chance of this, stated with the estimate: 25%; at least 5.0-fold (0.69 log units) between middle value and limit.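

In this assay, benzylamino in place of chloro on an aromatic carbon, next to the ring nitrogen and ortho to a cyano group, gives an at least 5.9-fold higher number from compound 3 to compound 4 (0.77 log units; beyond the scatter). Within the data shown here, this is the first measured step at this position, and it shows that the group placed there can move the read-out beyond the usual scatter, so the value of compound 3 is not set by the shared core alone. The size of the step is known only as a lower bound, because compound 4 sits at a limit of the assay and does not give a number: the limit of > 50000 nM in this assay, at which 1 of the 4 values shown sits.

From the compounds shown here alone, whether the change rests on the nitrogen that links benzylamino to the shared core or on its aromatic ring stays open, and a plain amino group or a benzyloxy group at this position would tell the two apart. Going by these compounds, how far compound 4 lies beyond its limit also stays open, as does whether a longer chain such as phenethylamino would give the same kind of step.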